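The source may report more compounds than this note shows. Statements on the series, on what has been measured and on what is new or still open speak of the compounds shown alone.

Compound 3 `C=CC(C)(C)c1[nH]c2c(C[C@H](O)C(C)(C)OC)cccc2c1/C=C1\NC(=O)[C@H](C)NC1=O` shares its core with compound 1 `C=CC(C)(C)c1[nH]c2ccc(C[C@H](O)C(C)(C)O)cc2c1/C=C1\NC(=O)[C@H](C)NC1=O` and compound 2 `C=CC(C)(C)c1[nH]c2ccc(C[C@H](OC(C)=O)C(C)(C)O)cc2c1/C=C1\NC(=O)[C@H](C)NC1=O`. In an ADME assay on MDCK cells (Canis lupus familiaris) for cytotoxicity, read by CellTiter-Glo, with a stated time of 40 h (on this read-out lower numbers stand for higher toxicity in this test and higher numbers for lower toxicity in this test), compound 1 reaches only the assay limit > 200000 nM. Compound 2 likewise gives only the limit > 200000 nM. Compound 3 also stands at the limit > 200000 nM, so all three values sit at the limit of > 200000 nM in this assay, at which 3 of the 3 values shown sit. Among the measured compounds shown here, the single step between measured compounds, a step that the two limits leave unreadable from compound 1 to compound 2, is unreadable for that reason. Compound 4 `C=CC(C)(C)c1[nH]c2ccccc2c1/C=C1\NC(=O)[C@H](C)NC1=O` differs from compound 3 by hydrogen in place of 2-hydroxy-3-methoxy-3-methylbutyl on an aromatic carbon. For the measured compounds named here, no measured step bears on this change, and the three limits give no direction. The step of a number no higher from compound 3 to compound 4 (the limit leaves the size open) is therefore expected to be none beyond the scatter. Compound 4 is expected to remain at 200000 nM, within a range from 50000 nM to 800000 nM.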

Compound 4, half-maximal cytotoxic concentration: > 200000 nM
Compound 4: only a limit was reported; the forecaster's own chance of this, stated with the estimate: 80%; the middle value sits exactly at the limit.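

Among the compounds shown here, no step to compound 4 from compound 1, compound 2 or compound 3 can be read, since each step joins two limits: the limit of > 200000 nM in this assay, at which 4 of the 4 values shown sit. As far as these compounds go, whether this assay separates these compounds at all remains open.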